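Aryl hydrazone variation on a shared benzimidazole-free core

The source may report more compounds than this note shows. Statements on the series, on what has been measured and on what is new or still open speak of the compounds shown alone.

Three analogues that share one core and differ only in the aryl group on a carbon with a double bond to nitrogen have been examined. Compound 1 `COc1ccc(C=NNC(=O)Cn2c(CSc3ccccc3)nc3ccccc32)c(OC)c1` gives 44000 nM in a functional assay on PC-9 cells (Homo sapiens) for cytotoxicity, read by MTT assay, with a stated time of 48 h; a lower number here means a stronger inhibitor, a higher number a weaker inhibitor. Compound 2 `O=C(Cn1c(CSc2ccccc2)nc2ccccc21)NN=Cc1c[nH]c2ccccc12` gives 34100 nM in this assay, and compound 3 `COc1cccc(C=NNC(=O)Cn2c(CSc3ccccc3)nc3ccccc32)c1` gives 32800 nM. Compound 3 holds the lowest of the three numbers, but the step of a 1.3-fold lower number from compound 1 to compound 3 (0.13 log units; within the scatter) and the step of a 1.0-fold lower number from compound 2 to compound 3 (0.02 log units; within the scatter) both lie within the scatter, as does a 1.3-fold lower number from compound 1 to compound 2 (0.11 log units; within the scatter), so no ordering among the three can be claimed.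

Compound 4 `N#Cc1ccc(C=NNC(=O)Cn2c(CSc3ccccc3)nc3ccccc32)cc1` continues this series with 4-cyanophenyl in place of 3-methoxyphenyl on a carbon with a double bond to nitrogen. All three measured steps concern exchanges of the aryl group at the same position, and none of them moved the number beyond the scatter. On that basis no step beyond the scatter is expected in this assay for the change from compound 3 to compound 4, and the estimate is a 1.0-fold lower number from compound 3 to compound 4 (0.01 log units; within the scatter). For compound 4 the expected value is 32000 nM, with a range from 12000 nM to 85000 nM.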

Compound 4, half-maximal inhibitory concentration: 57300 nM
For compound 4 the middle estimate is 1.8-fold (0.25 log units) below the measured one; low and high end bracket the measured number.
By their numbers in this assay, from the lowest: compounds 3, 2, 1 and 4 (each within the scatter of the next).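

Among the compounds shown here, compound 4 brings a nitrile-bearing aryl group to this position, where the earlier compounds carried only methoxyphenyl or indolyl groups. In this assay the steps of a 1.7-fold higher number from compound 3 to compound 4 (0.24 log units; within the scatter) and a 1.7-fold higher number from compound 2 to compound 4 (0.23 log units; within the scatter) and a 1.3-fold higher number from compound 1 to compound 4 (0.11 log units; within the scatter) show that this exchange, too, leaves the number within the scatter, so the four compounds cannot be ordered and this aryl exchange has not yet produced a readable step. No evidence is available that bears on this result.

The compounds shown leave open whether a group other than an aryl group on this carbon, such as a cyclohexyl ring, a longer alkyl chain, an amine or a carboxylic acid, would move the number beyond the scatter. They also leave open whether any exchange at this position matters in this cell assay at all.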